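The source may report more compounds than this note shows. Statements on the series, on what has been measured and on what is new or still open speak of the compounds shown alone.

In a functional assay on RAW264.7 cells (Mus musculus) for inhibition, read by Griess assay, with stated times of 3 h and 24 h; a higher number here means a weaker inhibitor, a lower number a stronger inhibitor:
- Compound 1 `C=C1CCC2[C@](C)(CO)[C@H](O)CC[C@@]2(C)[C@@H]1CCn1ccnc1`: > 50000 nM, a limit
- Compound 2 `C=C1CCC2[C@](C)(CO)[C@H](O)CC[C@@]2(C)[C@@H]1CCOc1ccccc1O`: 47700 nM
- Compound 3 `C=C1CCC2[C@](C)(CO)[C@H](O)CC[C@@]2(C)[C@@H]1CCOC(=O)c1cccnc1`: > 50000 nM, a limit

Compound 3 gives no number, only the limit > 50000 nM. This is the limit of > 50000 nM in this assay, at which 2 of the 3 values shown sit.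

Compound 4 `C=C1CCC2[C@](C)(CO)[C@H](O)CC[C@@]2(C)[C@@H]1CCOC(=O)c1ccccc1` differs from it by phenyl in place of pyridin-3-yl on a carbonyl carbon, with phenyl in place of pyridin-3-yl on a carbonyl carbon. Going by the values given here, no measured step makes this exact exchange. The nearest evidence is an at least 1.0-fold lower number from compound 1 to compound 2 (0.02 log units; that floor lies within the scatter) and an at least 1.0-fold higher number from compound 2 to compound 3 (0.02 log units; that floor lies within the scatter), and both floors lie within the scatter. The third, a step that the two limits leave unreadable from compound 1 to compound 3, cannot be read. No step beyond the scatter is therefore expected in this assay, and a further limit is quite possible. The expected step is a number no higher from compound 3 to compound 4 (the limit leaves the size open). For compound 4 the estimated value is 50000 nM, with an expected range of 22000 nM to 100000 nM.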

Compound 4, half-maximal inhibitory concentration: > 100000 nM
Compound 4: a limit, no number; the forecaster's own chance of this, stated with the estimate: 55%; at least 2.0-fold (0.30 log units) between middle value and limit.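

Going by these compounds alone, compound 4 sets a second, separate limit in this assay: the limit of > 100000 nM in this assay, at which 1 of the 4 values shown sits. Benzoyl in place of 2-hydroxyphenyl on the oxygen gives an at least 2.0-fold higher number from compound 2 to compound 4 (0.32 log units; beyond the scatter), the first readable step at this position that lies beyond the scatter. The steps reaching compound 4 from the two other limit compounds cannot be read, so phenyl in place of pyridin-3-yl has no readable size.

The compounds shown leave open whether that exchange matters at all in this series. They also leave open whether an amine, a carboxylic acid or a longer chain at this position would give a number in this assay rather than a limit.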